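The source may report more compounds than this note shows. Statements on the series, on what has been measured and on what is new or still open speak of the compounds shown alone.

Measured compounds in a functional assay on HepG2 cells (Homo sapiens) for cytotoxicity, read by MTT assay, with a stated time of 48 h; a lower number here means a stronger inhibitor, a higher number a weaker inhibitor:

Compound 1, `O=C(CSc1ncccn1)N1N=C(c2cc3ccccc3oc2=O)C[C@@H]1c1ccc(C(F)(F)F)cc1`: 4750 nM
Compound 2, `O=C(CSc1ccc(Br)cc1)N1N=C(c2cc3ccccc3oc2=O)C[C@@H]1c1ccc(C(F)(F)F)cc1`: 12700 nM
Compound 3, `CCCCSCC(=O)N1N=C(c2cc3ccccc3oc2=O)C[C@@H]1c1ccc(C(F)(F)F)cc1`: 8680 nM

The three compounds share one core and differ only in the group on the sulfur. Compound 3 sits in the middle of the three numbers, yet neither neighbour is clearly apart from it: the step of a 1.8-fold higher number from compound 1 to compound 3 (0.26 log units; within the scatter) and the step of a 1.5-fold lower number from compound 2 to compound 3 (0.17 log units; within the scatter) both stay within the scatter, so compound 3 cannot be ranked against compound 1 or compound 2. Within the data shown here, only the step of a 2.7-fold higher number from compound 1 to compound 2 (0.43 log units; beyond the scatter) goes beyond the scatter.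

Compound 4, `CCCCSCC(=O)N1N=C(c2cc3ccccc3oc2=O)C[C@@H]1c1ccccc1`, is not yet measured. It differs from compound 3 at the other end of the core: hydrogen in place of trifluoromethyl on an aromatic carbon. Among the measured compounds shown here, the measured steps all concern the group on the sulfur; none of them touches the six-membered aromatic ring of carbon only, so no step bears directly on this change. For that reason no direction can be read from the data, and the expected step of a 1.2-fold higher number from compound 3 to compound 4 (0.06 log units; within the scatter) is not expected to go beyond the scatter. Compound 4 is therefore estimated at 10000 nM in this assay, with a range from 4000 nM to 25000 nM.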

Compound 4, half-maximal inhibitory concentration: 6640 nM
The estimate for compound 4 lay 1.5-fold (0.18 log units) above the measured number; the measured number falls inside the stated range.
By their numbers in this assay, from the lowest: compounds 1, 4, 3 and 2 (each within the scatter of the next, the first and the last beyond it).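

In this assay, among these compounds, the step of a 1.3-fold lower number from compound 3 to compound 4 (0.12 log units; within the scatter) gives the only reading at the far end of the shared core, whereas the steps among compound 1, compound 2 and compound 3 all concerned the group on the sulfur. With butyl on the sulfur, taking away the trifluoromethyl, with its 4 heavy atoms, and leaving hydrogen on that aromatic carbon gives compound 4 a number that cannot be told apart from that of compound 3, so this pair gives no sign that the 4-(trifluoromethyl)phenyl group matters for the read-out here. No measurement shown speaks to why the two compounds read alike.

The compounds shown leave open whether hydrogen in place of trifluoromethyl gives a step of similar size when pyrimidin-2-yl or 4-bromophenyl, rather than butyl, sits on the sulfur. They also leave open what a methoxy group, an amine or a carboxylic acid would do at this place on the aromatic ring, and whether any of these would carry the number beyond the scatter.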